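The compounds below may be only part of what the source reports. "The series", "measured", "known", "first", "only" and "open" are said of these compounds alone.

Compound 1, `CC(C)(C)C(=O)N1CCN(c2nc(=O)c3cc(C(F)(F)F)cc([N+](=O)[O-])c3s2)CC1`, gives 5.87 ug/mL in a physicochemical assay for solubility, read by HPLC; a higher number here means a more soluble compound, a lower number a less soluble compound.
Compound 2, `O=C(c1ccccc1Cl)N1CCN(c2nc(=O)c3cc(C(F)(F)F)cc([N+](=O)[O-])c3s2)CC1`, gives 8.18 ug/mL in this assay.
Compound 3, `CCCCC(=O)N1CCN(c2nc(=O)c3cc(C(F)(F)F)cc([N+](=O)[O-])c3s2)CC1`, gives 42.5 ug/mL in this assay.

Compound 3 holds the highest of the three numbers in this assay: a 5.2-fold higher number from compound 2 to compound 3 (0.72 log units; beyond the scatter), and a 7.2-fold higher number from compound 1 to compound 3 (0.86 log units; beyond the scatter). Between the other two, a 1.4-fold higher number from compound 1 to compound 2 (0.14 log units; within the scatter). Compound 4, `CCCC(=O)N1CCN(c2nc(=O)c3cc(C(F)(F)F)cc([N+](=O)[O-])c3s2)CC1`, differs from compound 3 by hydrogen in place of methyl on a saturated chain carbon, three bonds along the chain from a carbonyl carbon. The two measured steps into compound 3 are the only ones that bear on this change, since both replace the group on the carbonyl carbon and both were modest and beyond the scatter; the change to compound 4 is a far smaller one, a shortening of the chain that stays within the same kind of group. On that basis only a small step, if any beyond the scatter, is expected in this assay for compound 4, with a slightly higher number the more likely direction. The step expected from compound 3 to compound 4 is a 1.3-fold higher number from compound 3 to compound 4 (0.11 log units; within the scatter). Compound 4 is therefore estimated at 55 ug/mL, with a range of 22 ug/mL to 130 ug/mL.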

Compound 4, solubility: 2.46 ug/mL
For compound 4 the middle estimate is 22-fold (1.35 log units) above the measured one; measured number below the stated range.
By their numbers in this assay, from the lowest: compound 4; then compounds 1 and 2 (each within the scatter of the next); then compound 3.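

In this assay, among these compounds, the group on the carbonyl carbon turns out to be sensitive to a very small edit: hydrogen in place of methyl on a saturated chain carbon, three bonds along the chain from a carbonyl carbon, gives a 17-fold lower number from compound 3 to compound 4 (1.24 log units; beyond the scatter), a larger step than any among the earlier compounds. The two straight chains also fall on opposite sides of the other two groups, with propyl in place of 2-chlorophenyl giving a 3.3-fold lower number from compound 2 to compound 4 (0.52 log units; beyond the scatter) and propyl in place of tert-butyl giving a 2.4-fold lower number from compound 1 to compound 4 (0.38 log units; beyond the scatter), so chain type alone does not order these compounds. No measurement shown here accounts for the step.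

With only propyl and butyl as straight chains, a shorter ethyl or a longer pentyl would be needed to tell a steady trend from a lone high point at butyl. Also open, as far as these compounds go, is how an amine or a carboxylic acid at the chain end would read.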